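The source may hold more compounds than are shown below. What is called first, only, known or untested is meant among the compounds shown, and "the series" means these compounds.

Of the compounds shown here, two have been measured so far. In an assay on microsomes from liver for inhibition of sterol O-acyltransferase 1 (Rattus norvegicus) (a higher number here means a weaker inhibitor, a lower number a stronger inhibitor), compound 1 `CCCCCCN(CCCCCSc1nc2c([nH]1)CCCC2)C(=O)Nc1ccc(F)cc1F` gives 810 nM. In this assay compound 2 `CCCCCCN(CCCCCSc1nc2cc(C)ccc2[nH]1)C(=O)Nc1ccc(F)cc1F` gives 1000 nM. Among the compounds with values here, the single measured step, a 1.2-fold higher number from compound 1 to compound 2 (0.09 log units; within the scatter), is the only comparison available. Within the data shown here, compound 2 thus holds the higher of the two numbers, but since its only neighbour, compound 1, sits within the scatter, no real difference between the two can be claimed.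

Compound 3 `CCCCCCN(CCCCCSc1nc2cc([N+](=O)[O-])ccc2[nH]1)C(=O)Nc1ccc(F)cc1F` has not been measured. It differs from compound 2 by nitro in place of methyl on an aromatic carbon. Among the measured compounds shown here, no measured step bears on this change: the one step on record, a 1.2-fold higher number from compound 1 to compound 2 (0.09 log units; within the scatter), alters the ring fused to the five-membered ring and says nothing about replacing a methyl by a nitro on that ring. The expectation for compound 3 therefore rests on the value of compound 2 alone, and the expected step of no change at the digits printed from compound 2 to compound 3 (within the scatter) is taken as none beyond the scatter, with a wide range to reflect the lack of evidence. Compound 3 is estimated at 1000 nM, most likely between 300 nM and 3500 nM.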

Compound 3, half-maximal inhibitory concentration: 2000 nM
Estimate against measurement, compound 3: 2.0-fold (0.30 log units) below, and the stated range covers the measured number.
By their numbers in this assay, from the lowest: compounds 1, 2 and 3 (each within the scatter of the next, the first and the last beyond it).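

In this assay, putting nitro where methyl stood on the aromatic carbon gives a 2.0-fold higher number from compound 2 to compound 3 (0.30 log units; within the scatter), so a group with hydrogen-bond acceptors can take the place of one without any, and the number stays within what repeat measurements would scatter. Exchanging the whole group on the sulfur gives a 2.5-fold higher number from compound 1 to compound 3 (0.39 log units; beyond the scatter), the first gap in this set to lie beyond the scatter, although it is modest and combines the change from a non-aromatic to an aromatic six-membered ring with the arrival of the nitro. Nothing measured here explains why any of these numbers sits where it does.

From the compounds shown here alone, only methyl and nitro have been seen at this position, so it remains open whether an amine, a carboxylic acid or a plain hydrogen there would give a number that stands clearly apart from those of compound 2 and compound 3. Also open, going by these compounds, is how a nitro on the non-aromatic six-membered ring of compound 1 would compare, which would help separate the two parts of the wider exchange.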